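This account rests on a few compounds, and the source may have more. Where it says the series, first, only, none or still open, it means among the compounds named here.

In an ADME assay on microsomes from liver (Mus musculus) for metabolic stability, read by HPLC, with a stated time of 4 h (a lower number here means slower removal, a higher number faster removal of the compound), three compounds with a shared core have been measured so far. Compound 1 `CN(C)c1ccc2cc(-c3ccccc3)c(N)nc2c1` reads > 500 mL/min/kg, which is a limit of the assay and not a number. Compound 2 `CN(C)c1ccc2cc(-c3ccccc3Cl)c(N)nc2c1` gives 420 mL/min/kg and compound 3 `CN(C)c1ccc2cc(-c3cccc(Cl)c3Cl)c(N)nc2c1` gives 360 mL/min/kg, so these two stand within the usual scatter of each other. Each measured step places chloro on an aromatic carbon in place of hydrogen. The first gives an at least 1.1-fold lower number from compound 1 to compound 2 (0.07 log units; that floor lies within the scatter), and the second gives a 1.2-fold lower number from compound 2 to compound 3 (0.07 log units; within the scatter).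

Compound 4 `CN(C)c1ccc2cc(-c3ccccn3)c(N)nc2c1` has not yet been measured. It carries pyridin-2-yl in place of 2-chlorophenyl on an aromatic carbon. Among the measured compounds shown here, the two chloro steps bear on this change only in part, since both concern chloro and no measured step brings in pyridin-2-yl. Neither step goes beyond the scatter, so a large move is not expected. The estimated change in this assay is a 1.3-fold lower number from compound 2 to compound 4 (0.12 log units; within the scatter), with no shift expected beyond the scatter. Compound 4 is estimated at 320 mL/min/kg, with an expected range from 160 mL/min/kg to 500 mL/min/kg.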

Compound 4, clearance: > 500 mL/min/kg
Compound 4 was reported as a limit; the forecaster's own chance of this, stated with the estimate: 15%; at least 1.5-fold (0.19 log units) between middle value and limit.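

In this assay compound 4 gives > 500 mL/min/kg, which is a limit of the assay and not a number. Until now, this position had shown only phenyl rings with or without chloro, and putting a ring with a hetero atom there gives an at least 1.1-fold higher number from compound 2 to compound 4 (0.07 log units; that floor lies within the scatter), so this change brings no lower number, though the true size of the step remains unknown. The step between compound 1 and compound 4 cannot be read because both compounds sit at the same limit: the limit of > 500 mL/min/kg in this assay, at which 2 of the 4 values shown sit.

From the compounds shown here alone, how far compound 4 lies beyond its limit remains open. Also open, going by these compounds, is whether pyridin-3-yl, a pyridin-2-yl ring bearing chloro, or a phenyl ring bearing an amine or a carboxylic acid would bring the clearance into the readable range.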